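Series notes: the step from compound 3 to compound 4

A few compounds are considered here, and "the series" means these few. Any claim that something is new, unique, unknown or untested is made for them only; others in the source may bear on it.

Within the data shown here, compound 3 `O=C(NNc1ccccc1)C1CCC(=O)N1S(=O)(=O)c1ccc(Cl)c(Cl)c1` stands second highest of the three numbers measured so far in a functional assay on the whole organism (Ehrlich cells) with Mus musculus as the target, at a dose of 50 mg/kg by the intraperitoneal route; on this read-out lower numbers stand for less inhibition and higher numbers for more inhibition at the one dose given (going by the name of the read-out): compound 3 gives 66.9%. Its nearest neighbour is compound 1 `NNC(=O)C1CCC(=O)N1S(=O)(=O)c1ccc(Cl)cc1`, which in this assay gives 64.9%, and the furthest is compound 2 `O=C(NNc1ccccc1)C1CCC(=O)N1S(=O)(=O)c1ccc(Cl)cc1`, which in this assay gives 74.3%. All three lie within the scatter of one another, so no order among them can be read from these numbers. The two measured steps are a number 9.4 percentage points higher from compound 1 to compound 2 (within the scatter) and a number 7.4 percentage points lower from compound 2 to compound 3 (within the scatter), each inside the scatter.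

Compound 4 `NNC(=O)C1CCC(=O)N1S(=O)(=O)c1ccc(Cl)c(Cl)c1` differs from compound 3 by hydrogen in place of phenyl on an amine nitrogen. Among the measured compounds shown here, only one measured step bears on this change, and it is the same change run the other way: a number 9.4 percentage points higher from compound 1 to compound 2 (within the scatter). Reversed, it points to a somewhat lower number for compound 4, of a size that stays inside the usual scatter. The chloro step does not touch the amine nitrogen and offers no further guidance.

Compound 4 is therefore expected to show 59% in this assay, with a range of 47% to 71%. The estimated step is a number 7.9 percentage points lower from compound 3 to compound 4 (within the scatter), not expected to exceed the scatter.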

Compound 4, a percentage reported as inhibition, in the whole organism at one dose (the size of the read-out at that dose, not a potency): 59.3%
Compound 4: middle estimate off by 0.3 percentage points, on the low side, and the stated range covers the measured number.
By their numbers in this assay, from the lowest: compounds 4, 1, 3 and 2 (each within the scatter of the next, the first and the last beyond it).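

In this assay, hydrogen in place of phenyl on the amine nitrogen now has a second reading, a number 7.6 percentage points lower from compound 3 to compound 4 (within the scatter), and it agrees in direction with the reading on the other core: the same change on two cores in this assay, a number 9.4 percentage points higher (within the scatter) from compound 1 to compound 2 and a number 7.6 percentage points higher (within the scatter) from compound 4 to compound 3, 1.8 percentage points apart, within the scatter of two such steps. The chloro change on the aromatic carbon also has a second reading, a number 5.6 percentage points lower from compound 1 to compound 4 (within the scatter), and it too agrees with the earlier step: the same change on two cores in this assay, a number 7.4 percentage points lower (within the scatter) from compound 2 to compound 3 and a number 5.6 percentage points lower (within the scatter) from compound 1 to compound 4, 1.8 percentage points apart, within the scatter of two such steps. Each single step stays within the scatter, so the series shows agreement between the two cores for both changes, but neither change, taken alone, separates a pair of compounds.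

Going by these compounds, it remains open whether another group on this amine nitrogen, such as methyl, benzyl or acetyl, would give a step beyond the scatter, and the same question stands for a methoxy or nitro group on the aromatic ring in place of chloro. With one dose in one whole-organism read-out, these numbers also leave potency open, as they give only the size of the inhibition at that dose.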